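Removing the methoxy from a benzothiazole aminopyrimidine

A few compounds are considered here, and "the series" means these few. Any claim that something is new, unique, unknown or untested is made for them only; others in the source may bear on it.

Compound 1 `COc1ccc2nc(Nc3ccnc(Nc4ccc(S(N)(=O)=O)cc4)n3)sc2c1`: 3030 nM
Compound 2 `Cc1ccc2nc(Nc3ccnc(Nc4ccc(S(C)(=O)=O)cc4)n3)sc2c1`: > 50000 nM

Within the data shown here, in a functional assay on PC-3 cells (Homo sapiens) for antiproliferative activity, read by MTT assay, with a stated time of 48 h (on this read-out higher numbers stand for weaker inhibition and lower numbers for stronger inhibition), compound 1 gives 3030 nM, the only number among the two measured compounds. Compound 2 gives > 50000 nM, which is a limit of this assay rather than a number; this is the limit described by the limit of > 50000 nM in this assay, at which 1 of the 2 values shown sits. Among the measured compounds shown here, compound 1 and compound 2 differ in more than one place, so their two values show only that compound 1 returns a number where compound 2 does not.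

Compound 3 `NS(=O)(=O)c1ccc(Nc2nccc(Nc3nc4ccccc4s3)n2)cc1` has not yet been tested. It differs from compound 1 in one place, (hydrogen in place of methoxy on an aromatic carbon). For the measured compounds named here, no measured pair shows the effect of a change of this kind. The change is expected to give a step from a 1.3-fold higher number from compound 1 to compound 3 (0.12 log units; within the scatter), which stays within the usual scatter. Compound 3 is therefore estimated at 4000 nM, with a likely range from 1500 nM to 12000 nM.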

Compound 3, half-maximal inhibitory concentration: 3100 nM
Beside the measured number, compound 3's estimate is 1.3-fold (0.11 log units) above it; measured number inside the range.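

In this assay, the replacement of methoxy by hydrogen on this aromatic carbon, meta to a fused ring and para to a fused ring, gives a 1.0-fold higher number from compound 1 to compound 3 (0.01 log units; within the scatter). Among these compounds, this is the first comparison that isolates a single change, and it shows that this position can carry hydrogen instead of methoxy with no change in the read-out beyond the scatter, so the number of compound 1 does not depend on its methoxy. Nothing measured here gives a reason for this result.

Going by these compounds, whether the position stays as tolerant with other groups remains open, since an amine, a carboxylic acid or a longer alkoxy chain on this carbon could behave differently. The compounds shown also leave open what a single change elsewhere on the core of compound 3 would do.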